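A few compounds are considered here, and "the series" means these few. Any claim that something is new, unique, unknown or untested is made for them only; others in the source may bear on it.

Among the compounds with values here, in a functional assay on the whole organism for inhibition, with Rattus norvegicus as the target, read by paw edema, with stated times of 30 min and 3 h, at a dose of 0.28 mmol/kg by the oral route (on this read-out lower numbers stand for less inhibition and higher numbers for more inhibition at the one dose given (going by the name of the read-out)), compound 1 `CNC(=O)c1nc(-c2cc(OC)c(OC)c(OC)c2)n(-c2ccc(OC)cc2)n1` gives 74%, while compound 2 `COc1ccc(-n2nc(C(=O)Nc3ccc(C)cc3)nc2-c2cc(OC)c(OC)c(OC)c2)cc1` gives 60%, the lower of the two numbers measured so far. Within the data shown here, the only measured step, a number 14 percentage points lower from compound 1 to compound 2 (beyond the scatter), changed a different group on the same amide-type nitrogen and does not bear directly on the present change. Compound 3 `COc1ccc(-n2nc(C(=O)Nc3ccccc3C)nc2-c2cc(OC)c(OC)c(OC)c2)cc1` differs from compound 2 by 2-methylphenyl in place of 4-methylphenyl on an amide-type nitrogen. Among the measured compounds shown here, with no comparable step measured, the expected step in this assay is no change at the digits printed from compound 2 to compound 3 (within the scatter), none beyond the scatter. Compound 3 is therefore estimated at 60%, within a range from 45% to 75%.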

Compound 3, a percentage reported as inhibition, in the whole organism at one dose (the size of the read-out at that dose, not a potency): 50%
For compound 3 the middle estimate is 10 percentage points above the measured one; low and high end bracket the measured number.
By their numbers in this assay, from the lowest: compounds 3 and 2 (each within the scatter of the next); then compound 1.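

In this assay, 2-methylphenyl in place of 4-methylphenyl on the amide-type nitrogen gives a number 10 percentage points lower from compound 2 to compound 3 (within the scatter), so this assay does not separate the two methylphenyl groups. With methyl on that nitrogen replaced by 2-methylphenyl, there is a number 24 percentage points lower from compound 1 to compound 3 (beyond the scatter), so both methylphenyl compounds now stand beyond the scatter from compound 1, and none of the three compounds goes against this. Nothing available explains these numbers. Still open, on these data alone, is how an ethyl group or an unsubstituted phenyl on this nitrogen would read, which would show whether the lower numbers follow the ring itself or its methyl.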